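Fluoro for methyl on the core of compound 1

The source may report more compounds than this note shows. Statements on the series, on what has been measured and on what is new or still open speak of the compounds shown alone.

Compound 1 `Cc1cnc(Nc2ccc(S(C)(=O)=O)cc2)nc1Nc1nc2ccc(F)cc2s1` is the reference point of this set. In a functional assay on MDA-MB-231 cells (Homo sapiens) for antiproliferative activity, read by MTT assay, with a stated time of 48 h (a higher number here means a weaker inhibitor, a lower number a stronger inhibitor), compound 1 gives > 50000 nM, which is a limit of the assay rather than a number, namely (the limit of > 50000 nM in this assay, at which 1 of the 3 values shown sits). Compound 2 `Cc1cnc(Nc2ccc(S(C)(=O)=O)cc2)nc1Nc1nc2ccccc2s1` gives 14800 nM in this assay, and the step of an at least 3.3-fold lower number from compound 1 to compound 2 (0.52 log units; beyond the scatter) lies beyond the scatter. Compound 3 `Cc1cnc(Nc2ccc(S(N)(=O)=O)cc2)nc1Nc1nc2ccc(F)cc2s1` gives 7580 nM in this assay, and the step of an at least 6.5-fold lower number from compound 1 to compound 3 (0.81 log units; beyond the scatter) also lies beyond the scatter. Compound 4 `CS(=O)(=O)c1ccc(Nc2ncc(F)c(Nc3nc4ccc(F)cc4s3)n2)cc1` differs from compound 1 by fluoro in place of methyl on an aromatic carbon. Neither measured step bears on this change: one alters the fluoro on an aromatic carbon of the fused ring, the other the methyl on the sulfonyl sulfur, and both leave the methyl on the core untouched. With nothing to point in either direction, no step beyond the scatter is expected, and the estimate is anchored to the limit of compound 1 alone. Compound 4 is therefore expected in this assay at 45000 nM, within a range from 15000 nM to 150000 nM. The implied step an at least 1.1-fold lower number from compound 1 to compound 4 (0.04 log units; that floor lies within the scatter) is an estimate only, with a real chance that compound 4 again returns a limit.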

Compound 4, half-maximal inhibitory concentration: 8900 nM
Estimate against measurement, compound 4: 5.1-fold (0.70 log units) above; measured number outside the range, below it.
By their numbers in this assay, from the lowest: compounds 3, 4 and 2 (each within the scatter of the next). At a limit, above all of these: compound 1.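

In this assay, fluoro in place of methyl on an aromatic carbon of the core gives an at least 5.6-fold lower number from compound 1 to compound 4 (0.74 log units; beyond the scatter), so this position, left untouched in compound 2 and compound 3, also responds to a single change. That makes compound 4 the third single change from compound 1, after compound 2 and compound 3, to give a measured number instead of a limit. The step is a floor rather than a size, since compound 1 stands at a limit: the limit of > 50000 nM in this assay, at which 1 of the 4 values shown sits.

Open, going by these compounds, is whether fluoro itself matters or only the loss of methyl, a question that a hydrogen or a chloro at this position would help to settle. Also open, on these data alone, is whether fluoro here and amino on the sulfonyl sulfur add up when combined in one compound.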